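Indazolyl ureas on an indane core: chloro to methoxy

The source may report more compounds than this note shows. Statements on the series, on what has been measured and on what is new or still open speak of the compounds shown alone.

Measured compounds:
compound 1, `O=C(Nc1cccc2[nH]ncc12)NC1CCc2cc(Br)ccc21`, 9 nM
compound 2, `CC(C)(CO)c1ccc2c(c1)CC[C@H]2NC(=O)Nc1cccc2[nH]ncc12`, 127 nM
compound 3, `O=C(Nc1cccc2[nH]ncc12)NC1CCc2cc(Cl)ccc21`, 10 nM

Three ureas sharing one core have been tested in an assay on isolated protein for inhibition of transient receptor potential cation channel subfamily V member 1 (Homo sapiens), read by calcium flux; a lower number here means a stronger inhibitor, a higher number a weaker inhibitor. Compound 1 gives 9 nM, compound 3 gives 10 nM, and the two sit within the scatter of each other, the step being a 1.1-fold higher number from compound 1 to compound 3 (0.05 log units; within the scatter). Compound 2, which carries a larger substituent at the same place on the core, gives 127 nM, a number far from that of compound 3 and beyond the scatter. Compound 3 thus stands close to compound 1 and well apart from compound 2.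

Compound 4, `COc1ccc2c(c1)CCC2NC(=O)Nc1cccc2[nH]ncc12`, is not yet measured. It differs from compound 3 by methoxy in place of chloro on an aromatic carbon. Going by the values given here, no measured step exchanges a halogen for a methoxy group, so only the two steps above inform the expectation: the halogen swap in this assay was within the scatter, while the bulkier group in compound 2 gave a number well above that of compound 3. Compound 4 is therefore expected to give a moderately higher number than compound 3, a step of a 4.0-fold higher number from compound 3 to compound 4 (0.60 log units; beyond the scatter), with an estimate of 40 nM and a range from 12 nM to 150 nM.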

Compound 4, half-maximal inhibitory concentration: 40 nM
Estimate against measurement, compound 4: no gap at the digits printed; low and high end bracket the measured number.
By their numbers in this assay, from the lowest: compounds 1 and 3 (each within the scatter of the next); then compound 4; then compound 2.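

In this assay, methoxy in place of chloro gives a 4.0-fold higher number from compound 3 to compound 4 (0.60 log units; beyond the scatter), and methoxy in place of bromo gives a 4.4-fold higher number from compound 1 to compound 4 (0.65 log units; beyond the scatter). The earlier swap between the two halogens stayed within the scatter, whereas this change shows that the position does distinguish between substituents, even though the step is modest: methoxy, which brings two heavy atoms and a hydrogen-bond acceptor, stands apart from both chloro and bromo. Nothing available here bears on the cause of this step.

With methoxy as the only oxygen-bearing group at this position among these ureas, the compounds shown cannot separate the effect of the oxygen from that of the added atom count. As far as these compounds go, how a methyl, an ethoxy or a dimethylamino group would compare at the same position remains open.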